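The compounds below may be only part of what the source reports. "The series", "measured", "known", "first", "only" and "open" are said of these compounds alone.

Compound 1 `C[C@H](NC(=O)CN(c1nc(Cl)nc2[nH]cnc12)C1CC1)C(=O)OCc1ccccc1` — 23%
Compound 2 `O=C(CN(c1nc(Cl)nc2[nH]cnc12)C1CC1)NCC(=O)OCc1ccccc1` — 18%

Both numbers come from a functional assay on the whole organism (Tail, strain ICR) with Mus musculus as the target, in the tail flick test, with a stated time of 150 min, at a dose of 25 umol/kg by the oral route; on this read-out lower numbers stand for a weaker effect and higher numbers for a stronger effect at the one dose given. Going by the values given here, compound 2 gives 18%; the only other number is that of compound 1, which gives 23%. The step of a number 5 percentage points lower from compound 1 to compound 2 (within the scatter) is within the scatter, so the two stand level and compound 2 cannot be set apart from compound 1 on these data.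

Compound 3 `CC(C)[C@H](NC(=O)CN(c1nc(Cl)nc2[nH]cnc12)C1CC1)C(=O)OCc1ccccc1` is not yet measured. It differs from compound 2 by isopropyl in place of hydrogen on a saturated chain carbon bound to an amide-type nitrogen and a carbonyl carbon. Among the compounds with values here, the one measured step at this place, a number 5 percentage points lower from compound 1 to compound 2 (within the scatter), is within the scatter, and no other measured pair bears on an isopropyl there. On that basis no step beyond the scatter is expected, and the estimated step is a number 4 percentage points higher from compound 2 to compound 3 (within the scatter). Compound 3 is therefore estimated at 22%, with an expected range from 8% to 38%.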

Compound 3, a percentage reported as activity, at one dose (the size of the read-out at that dose, not a potency): 17.9%
Estimate against measurement, compound 3: 4.1 percentage points above; the range from low to high includes it.
By their numbers in this assay, from the lowest: compounds 3, 2 and 1 (each within the scatter of the next).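

Isopropyl on the saturated chain carbon bound to an amide-type nitrogen and a carbonyl carbon reads level with hydrogen in this assay (a number 0.1 percentage points lower from compound 2 to compound 3 (within the scatter)) and level with methyl (a number 5.1 percentage points lower from compound 1 to compound 3 (within the scatter)). Hydrogen, methyl and isopropyl at this place therefore cannot be told apart in this read-out at the one dose and time given, so the level result no longer rests on the single step between methyl and hydrogen. Nothing measured on these compounds offers an explanation for this level read-out.

Still open, as far as these compounds go, is whether another kind of group at this place, such as an amine, a carboxylic acid or a longer chain, would give a step beyond the scatter. Also open, from the compounds shown here alone, is whether these three compounds would separate at another dose or time.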